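Swapping the Aryl Group on a Dopamine Receptor Agonist

The compounds below may be only part of what the source reports. "The series", "measured", "known", "first", "only" and "open" are said of these compounds alone.

Measured compounds:
Compound 1 `COc1ccccc1C1CCN(CC(=O)Nc2cccc(C)c2)CC1` gives 420 nM
Compound 2 `O=C(CN1CCC(c2cccc[n+]2[O-])CC1)NC1CCCCC1` gives 294 nM
Compound 3 `C=Cc1cccc(C(=O)NCN2CCC(c3cccc[n+]3[O-])CC2)c1` gives 68 nM

These three compounds were tested in a functional assay on HEK293 cells for agonist activity at D(4) dopamine receptor (Homo sapiens), read by FLIPR; a lower number here means that less compound is needed, a higher number that more compound is needed for the effect. Among them compound 1 has the highest number. Compound 2 lies within the scatter of compound 1, so the two cannot be told apart. Compound 3 is set apart from compound 1 by a gap beyond the scatter, and its lower number means that less of compound 3 is needed.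

Compound 4 `Cc1cccc(NC(=O)CN2CCC(c3cccc(O)c3)CC2)c1` has not yet been measured. It differs from compound 1 in one place: 3-hydroxyphenyl in place of 2-methoxyphenyl on a saturated ring carbon. A group with one hydrogen-bond donor replaces one with none, on the same saturated ring carbon.

Within the data shown here, no measured pair shows this exact change, so the expectation rests on compound 1 alone. The other two compounds carry a different aryl group and give no direct guide. The step from compound 1 to compound 4 in this assay is expected to be small, a 1.2-fold lower number from compound 1 to compound 4 (0.08 log units; within the scatter), and not clearly beyond the scatter in either direction. Compound 4 is therefore estimated at 350 nM, with a range from 100 nM to 1200 nM.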

Compound 4, half-maximal effective concentration: 8 nM
For compound 4 the middle estimate is 44-fold (1.64 log units) above the measured one; the whole stated range lies above it.
By their numbers in this assay, from the lowest: compound 4; then compound 3; then compounds 2 and 1 (each within the scatter of the next).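

In this assay, the group on this saturated ring carbon turns out to matter a great deal: 3-hydroxyphenyl in place of 2-methoxyphenyl gives a 53-fold lower number from compound 1 to compound 4 (1.72 log units; beyond the scatter), with the rest of the molecule unchanged. Compound 1, compound 2 and compound 3 could not show this, since no two of them differ in only one place. Nothing given here accounts for the size of this step.

The change swaps methoxy for hydroxy and also alters where the oxygen group stands on the phenyl ring, and the compounds shown do not separate these two parts of the change. They also leave open whether an amine or a carboxylic acid in place of the hydroxy group would keep a number as low as that of compound 4 in this assay.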